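Exposure in Monkey: the Step from Compound 1 to Compound 4

The source may report more compounds than this note shows. Statements on the series, on what has been measured and on what is new or still open speak of the compounds shown alone.

Three compounds that share one core have been followed in an ADME assay on the whole organism (Macaca fascicularis) for pharmacokinetics, read by LC-MS, using cassette dosing, at a dose of 1 mg/kg by the oral route; a lower number here means less compound in the circulation, a higher number more compound in the circulation at the dose given. Compound 1 `CCCCN(c1nc2c(C(=O)O)cccc2o1)[C@H](C)c1ccc(-c2ccccc2-c2nnn[nH]2)cc1` gives 429 ng.h/mL, the lowest of the three numbers. Compound 3 `CCCCN(c1nc2c(C(=O)O)cccc2o1)[C@H](C)c1ccc(-c2cc(Cl)ccc2-c2nc(=O)o[nH]2)cc1` gives 1040 ng.h/mL, a higher number than compound 1 and beyond the scatter. Compound 2 `Cc1ccc(-c2nc(=O)o[nH]2)c(-c2ccc([C@@H](C)N(CC3CC3)c3nc4c(C(=O)O)cccc4o3)cc2)c1` gives 4830 ng.h/mL, the highest of the three and the furthest from compound 1, also beyond the scatter. For the measured compounds named here, compound 2 and compound 3 each differ from compound 1 in more than one place, so their numbers stand on their own and define no single step.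

Compound 4 `CCCCN(c1nc2c(C(=O)NS(C)(=O)=O)cccc2o1)[C@H](C)c1ccc(-c2ccccc2-c2nnn[nH]2)cc1` has not yet been measured in this assay. It differs from compound 1 in one place only: methanesulfonamido in place of hydroxy on a carbonyl carbon. Read one bond further out, the carboxy group of compound 1 becomes a (methylsulfonyl)carbamoyl group.

Going by the values given here, no measured pair shows this change, so there is nothing to lean on but the number of compound 1 itself. The expected step of a 1.1-fold lower number from compound 1 to compound 4 (0.05 log units; within the scatter) is small, with no direction claimed beyond the scatter, and the range is kept wide. Compound 4 is therefore expected to give 380 ng.h/mL, between 110 ng.h/mL and 1300 ng.h/mL.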

Compound 4, area under the concentration-time curve: 22.2 ng.h/mL
The estimate for compound 4 lay 17-fold (1.23 log units) above the measured number, outside the stated range (below it).
By their numbers in this assay, from the lowest: compound 4; then compound 1; then compound 3; then compound 2.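

In this assay, for the compounds shown here, replacing hydroxy on the carbonyl carbon with methanesulfonamido gives a 19-fold lower number from compound 1 to compound 4 (1.29 log units; beyond the scatter), the only step in this set that changes one place alone. It shows that this position is not indifferent to what stands on the carbonyl carbon: with the rest of compound 1 held constant, turning carboxy into (methylsulfonyl)carbamoyl is enough to cause a large loss of compound in the circulation, something the earlier numbers, whose compounds differ in several places, could not isolate. Nothing measured here accounts for the size of this step.

The compounds shown leave open whether the loss follows from the methanesulfonamido group itself or from any replacement of hydroxy at this place, such as an amine giving a plain carboxamide, or a sulfonamide carrying a longer chain than methyl. They also leave open whether the same change would produce a step of similar size on compound 2 or compound 3, which keep the carboxy group but differ from compound 1 elsewhere.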